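The compounds below may be only part of what the source reports. "The series", "measured", "known", "first", "only" and "open" are said of these compounds alone.

Of the compounds shown here, three built on one shared core have been tested in an assay on HEK293 cells for displacement of a labelled ligand from Melanocortin receptor 4 (Homo sapiens); a lower number here means a stronger inhibitor, a higher number a weaker inhibitor. Compound 1 `CC(C)C[C@H](N)c1cc(C(F)(F)F)ccc1N1CCN(C(=O)CNc2ccccc2)CC1` gives 3600 nM, the second highest of the three numbers. Compound 3 `CC(C)C[C@H](N)c1cc(C(F)(F)F)ccc1N1CCN(C(=O)CCNC2CCCCC2)CC1` gives 4800 nM, and a 1.3-fold higher number from compound 1 to compound 3 (0.12 log units; within the scatter). Compound 2 `COc1ccc(CC(C)C(=O)N2CCN(c3ccc(C(F)(F)F)cc3[C@@H](N)CC(C)C)CC2)cc1` gives 120 nM, and a 30-fold lower number from compound 1 to compound 2 (1.48 log units; beyond the scatter). Compound 4 `Cc1ccc(OCC(=O)N2CCN(c3ccc(C(F)(F)F)cc3[C@@H](N)CC(C)C)CC2)c(C)c1` has not yet been measured; it differs from compound 1 in one place: 2,4-dimethylphenoxy in place of anilino on a saturated chain carbon bound to a carbonyl carbon. Of the measured steps, a 30-fold lower number from compound 1 to compound 2 (1.48 log units; beyond the scatter) bears most on this change, as in both a new ring of carbon only arrives in place of the anilino group, while a 1.3-fold higher number from compound 1 to compound 3 (0.12 log units; within the scatter) bears little. A lower number is therefore expected for compound 4, a 9.0-fold lower number from compound 1 to compound 4 (0.95 log units; beyond the scatter). Compound 4 is estimated at 400 nM, between 100 nM and 1600 nM.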

Compound 4, inhibition constant: 4000 nM
For compound 4 the middle estimate is 10-fold (1.00 log units) below the measured one; the whole stated range lies below it.
By their numbers in this assay, from the lowest: compound 2; then compounds 1, 4 and 3 (each within the scatter of the next).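

In this assay, 2,4-dimethylphenoxy in place of anilino on this saturated chain carbon stays within the scatter (a 1.1-fold higher number from compound 1 to compound 4 (0.05 log units; within the scatter)), and compound 4 also sits within the scatter of compound 3 (a 1.2-fold lower number from compound 3 to compound 4 (0.08 log units; within the scatter)). Losing the anilino hydrogen-bond donor and adding two heavy atoms therefore shifts nothing measurable here. Compound 2 stays apart (a 33-fold higher number from compound 2 to compound 4 (1.52 log units; beyond the scatter)), so a new aromatic ring alone does not carry its low number over to compound 4. Still open, from the compounds shown here alone, is whether a plain benzyl group on the carbonyl carbon would keep that low number. No measurement shown gives a reason for these numbers.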